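Carrying One Methoxy Step from One Core to Another

The compounds below may be only part of what the source reports. "The series", "measured", "known", "first", "only" and "open" are said of these compounds alone.

Compound 1 `O=C(CCc1cccc2c1B(O)OC2)Nc1ccccc1` gives 350 nM in a functional assay on HCT-116 cells (Homo sapiens) for antiproliferative activity, read by MTT assay, with a stated time of 72 h; on this read-out lower numbers stand for stronger inhibition and higher numbers for weaker inhibition. Compound 2 `COc1ccccc1NC(=O)CCc1cccc2c1B(O)OC2` differs from it by methoxy in place of hydrogen on an aromatic carbon, and in this assay compound 2 gives 430 nM; the resulting step of a 1.2-fold higher number from compound 1 to compound 2 (0.09 log units; within the scatter) is small. Compound 3 `COc1cccc(-c2cccc(NC(=O)CCc3ccc4c(c3)COB4O)c2)c1` rests on a different core, and the difference between the two cores is not broken down here. In this assay compound 3 gives 81000 nM, which is the highest of the three numbers and stands far from both compound 1 and compound 2.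

Compound 4 `COc1cc(OC)cc(-c2cccc(NC(=O)CCc3ccc4c(c3)COB4O)c2)c1` is the not yet measured partner of compound 3 and differs from it by methoxy in place of hydrogen on an aromatic carbon. This is the same kind of change as that from compound 1 to compound 2, but the surroundings are not identical: in compound 2 the new group sits ortho to a large group, whereas in compound 4 it sits meta to a large group and meta to a methoxy group. On the strength of a 1.2-fold higher number from compound 1 to compound 2 (0.09 log units; within the scatter), the step of a 1.1-fold higher number from compound 3 to compound 4 (0.05 log units; within the scatter) is expected to stay within the scatter. Compound 4 is therefore estimated at 90000 nM in this assay, expected to fall between 40000 nM and 200000 nM.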

Compound 4, half-maximal inhibitory concentration: 56000 nM
Compound 4: middle estimate off by 1.6-fold (0.21 log units), on the high side, within the range that was stated.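

In this assay the new step is a 1.4-fold lower number from compound 3 to compound 4 (0.16 log units; within the scatter), so adding the methoxy leaves the reading unmoved on this core, as it did on the core of compound 1. Set side by side, the two steps do not differ: the same change on two cores in this assay, a 1.2-fold higher number (0.09 log units; within the scatter) from compound 1 to compound 2 and a 1.4-fold lower number (0.16 log units; within the scatter) from compound 3 to compound 4, 1.8-fold (0.25 log units) apart, within the scatter of two such steps. This shows that the change carries across the two cores in these two pairs, but two pairs with the new group in different surroundings do not make a rule for the series, and they do not tell how the two cores themselves compare.

The compounds shown leave open whether an amine, a carboxylic acid or a longer chain in place of the methoxy would also leave the number unmoved on either core. Going by these compounds, it also remains open whether a methoxy on another carbon of the same ring in compound 3 would behave as it does in compound 4.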